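Thiophen-2-yl to 6-Fluoropyridin-3-yl: a Step from Compound 1

The compounds below may be only part of what the source reports. "The series", "measured", "known", "first", "only" and "open" are said of these compounds alone.

The study begins with compound 1 `CCN(c1ccc(C#N)c(Cl)c1)c1cc(-c2cccs2)ccc1C`, a diarylamine carrying a nitrile and a chloro substituent on one ring. In a functional assay on PC-3 cells (Homo sapiens) for antiproliferative activity, read by CCK-8 assay, with a stated time of 6 days (a lower number here means a stronger inhibitor, a higher number a weaker inhibitor), compound 1 gives only a limit, > 30000 nM, and no single number. This limit is the only quantitative mark so far (the limit of > 30000 nM in this assay, at which 1 of the 3 values shown sits). Two further compounds are described without a result: compound 2 `N#Cc1ccc(N2CCc3cc(-c4cncnc4)ccc3C2)cc1C(F)(F)F`, for which this assay returns "not determined" (no result reported), and compound 3 `Cc1noc(C)c1-c1cccc2c1CCCN2c1ccc(C#N)c(C(F)(F)F)c1`, for which this assay likewise returns "not determined" (no result reported). Compound 1 therefore stands at the edge of what this assay can resolve, with nothing else to compare it to.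

Compound 4 `CCN(c1ccc(C#N)c(Cl)c1)c1cc(-c2ccc(F)nc2)ccc1C` is not yet measured. It differs from compound 1 in one place: 6-fluoropyridin-3-yl in place of thiophen-2-yl on an aromatic carbon. Since compound 1 shows only a limit, the step from it can be expected only loosely; a shift of an at least 1.5-fold lower number from compound 1 to compound 4 (0.17 log units; that floor lies within the scatter) is estimated, which may still leave compound 4 near the limit. Compound 4 is expected to give about 20000 nM in this assay, within a range from 3000 nM to 60000 nM.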

Compound 4, half-maximal inhibitory concentration: > 30000 nM
Compound 4 gave a limit, no number; the forecaster's own chance of this, stated with the estimate: 55%; middle value at least 1.5-fold (0.17 log units) from the limit.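

Among the compounds shown here, compound 1 and compound 4 each give only a limit in this assay, so no step between them can be read: the limit of > 30000 nM in this assay, at which 2 of the 4 values shown sit. The compounds shown leave open whether any group in place of thiophen-2-yl on the shared core gives a single number in this assay.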